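The source may report more compounds than this note shows. Statements on the series, on what has been measured and on what is new or still open speak of the compounds shown alone.

Measured so far:
compound 1, `CCCn1c(-c2ccco2)nc2c(N)ncnc21`: 790 nM
compound 2, `CCCn1c(Br)nc2c(N)nc(NCCCc3ccccc3)nc21`: 1950 nM
compound 3, `CCCn1cnc2c(NCc3ccccc3)ncnc21`: 29100 nM

All three compounds share a core and were tested in an assay on CHO cells for displacement of a labelled ligand from transmembrane domain-containing protein TMIGD3 (Homo sapiens); on this read-out higher numbers stand for weaker inhibition and lower numbers for stronger inhibition. Compound 1 gives 790 nM and compound 2 gives 1950 nM in this assay, while compound 3 gives 29100 nM, the highest of the three numbers; its gaps to compound 2 and to compound 1 both lie beyond the usual scatter, so compound 3 is the weakest inhibitor of the three.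

Compound 4, `CCCn1c(-c2ccco2)nc2c(NCc3ccccc3)ncnc21`, has not yet been measured. It differs from compound 3 in one place: furan-2-yl in place of hydrogen on an aromatic carbon. Within the data shown here, no pair of measured compounds differing only in this way exists, so the size of the step has to be guessed. Compound 1 carries the same furan-2-yl group and gives 790 nM, but it also differs from compound 3 elsewhere, so that number cannot be read as the effect of the furan alone. The step from compound 3 to compound 4 is expected to be a 9.7-fold lower number from compound 3 to compound 4 (0.99 log units; beyond the scatter), towards stronger inhibition. Compound 4 is accordingly expected to give about 3000 nM in this assay, with a plausible range from 500 nM to 15000 nM.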

Compound 4, inhibition constant: 402 nM
Compound 4: the middle estimate sits 7.5-fold (0.87 log units) above what was measured; the whole stated range lies above it.
By their numbers in this assay, from the lowest: compounds 4 and 1 (each within the scatter of the next); then compound 2; then compound 3.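

In this assay, furan-2-yl in place of hydrogen on the aromatic carbon between two ring nitrogen atoms gives a 72-fold lower number from compound 3 to compound 4 (1.86 log units; beyond the scatter), a large change that shows this position strongly influences the read-out when the benzyl group is present. With furan-2-yl in place, benzyl in place of hydrogen on the nitrogen gives a 2.0-fold lower number from compound 1 to compound 4 (0.29 log units; within the scatter), which lies within the usual scatter, so compounds 1 and 4 cannot be told apart and this change has no clear effect on inhibition here. No measurement shown explains why the furan-2-yl change has such a large effect.

From the compounds shown here alone, it remains open whether a phenyl ring, a thiophene ring or a methyl group on the same carbon would match furan-2-yl. Going by these compounds, it is also open whether furan-2-yl would give a step of similar size on the core without the benzyl group.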